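A Fluorine Added Beside the Amide of Compound 3

The source may hold more compounds than are shown below. What is called first, only, known or untested is meant among the compounds shown, and "the series" means these compounds.

Measured so far in a functional assay on Bel-7402 cells (Homo sapiens) for cytotoxicity, read by MTT assay; on this read-out lower numbers stand for stronger inhibition and higher numbers for weaker inhibition:
compound 1, `CCn1cc(C(=O)Nc2ccccc2)c(=O)c2cc(F)c(N3CCNC(C)C3)c(F)c21`: 6000 nM
compound 2, `CCn1cc(C(=O)Nc2ccc(Cl)cn2)c(=O)c2cc(F)c(N3CCNC(C)C3)c(F)c21`: 4900 nM
compound 3, `CCn1cc(C(=O)Nc2cccc([N+](=O)[O-])c2)c(=O)c2cc(F)c(N3CCNC(C)C3)c(F)c21`: 1000 nM

Compound 3 stands lowest of the three numbers in this assay. Its nearest neighbour is compound 2, as seen in a 4.9-fold lower number from compound 2 to compound 3 (0.69 log units; beyond the scatter); the furthest is compound 1, as seen in a 6.0-fold lower number from compound 1 to compound 3 (0.78 log units; beyond the scatter). Compound 4, `CCn1cc(C(=O)Nc2cc([N+](=O)[O-])ccc2F)c(=O)c2cc(F)c(N3CCNC(C)C3)c(F)c21`, is not yet measured. It differs from compound 3 by fluoro in place of hydrogen on an aromatic carbon.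

Among the measured compounds shown here, none of the measured steps adds a fluoro group to this ring, so no step bears directly on the change. What the steps do show is that swapping the whole aryl group for another without a nitro group changed little, a 1.2-fold lower number from compound 1 to compound 2 (0.09 log units; within the scatter), while bringing in the nitro group gave the modest step of a 6.0-fold lower number from compound 1 to compound 3 (0.78 log units; beyond the scatter). Compound 4 keeps the nitro group and adds only a single fluorine. The expected step of no change at the digits printed from compound 3 to compound 4 (within the scatter) is therefore none beyond the scatter. Compound 4 is estimated at 1000 nM in this assay, with a range from 400 nM to 2500 nM.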

Compound 4, half-maximal inhibitory concentration: 2900 nM
Beside the measured number, compound 4's estimate is 2.9-fold (0.46 log units) below it, outside the stated range (above it).
By their numbers in this assay, from the lowest: compound 3; then compounds 4, 2 and 1 (each within the scatter of the next, the first and the last beyond it).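

In this assay, this position on the nitro-bearing ring turns out to matter: a single fluoro, ortho to a large group and para to a nitro group, gives a 2.9-fold higher number from compound 3 to compound 4 (0.46 log units; beyond the scatter), so part of the gain that came with the nitro group is lost. Compound 4 still keeps an edge over the plain phenyl, with a 2.1-fold lower number from compound 1 to compound 4 (0.32 log units; beyond the scatter), whereas a 1.7-fold lower number from compound 2 to compound 4 (0.23 log units; within the scatter) lies within the scatter, so compound 4 cannot be told apart from the 5-chloropyridin-2-yl compound. Nothing available explains how one added atom moves the number.

Open, as far as these compounds go, is whether the shift is particular to fluorine, or whether a chloro, methyl or methoxy group at this place would move the number in the same way. Also open, from the compounds shown here alone, is whether fluoro at this place would act alike on the plain phenyl of compound 1, without the nitro group.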